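This account rests on a few compounds, and the source may have more. Where it says the series, first, only, none or still open, it means among the compounds named here.

Working notes on a small series sharing one core. In a functional assay on HCT-116 cells (Homo sapiens) for cytotoxicity (on this read-out lower numbers stand for an effect already at smaller amounts and higher numbers for an effect only at larger amounts of compound), compound 1 (`CC(=O)SCC(=O)c1ccc(S(=O)(=O)Nc2ccc(OC(F)(F)F)cc2)cc1`) gives 16100 nM and compound 2 (`CC(=O)SCC(=O)c1ccc(NS(=O)(=O)c2ccc(Cl)cc2)cc1`) gives 30800 nM. Compound 3 (`CC(=O)SCC(=O)c1ccc(NS(=O)(=O)c2cccc(OC(F)(F)F)c2)cc1`) has no usable number, and its result stands as "not determined" (no result reported). Going by the values given here, compound 2 therefore lies within the usual scatter of compound 1, and these are the only two numbers available. Among the compounds with values here, no two measured compounds differ in one place, so the series gives no direct measure of what a single substitution does.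

Compound 4 (`COc1ccc(S(=O)(=O)Nc2ccc(C(=O)CSC(C)=O)cc2)cc1`) has not yet been measured. It keeps the frame of compound 2 and changes one substituent, with 4-chlorophenyl becoming 4-methoxyphenyl: methoxy in place of chloro on an aromatic carbon, para to a large group (methoxy in place of chloro on an aromatic carbon).

In this assay, no step beyond the scatter is expected in either direction. The expectation is anchored on compound 2 at 30800 nM, the closest measured structure, and the data offer no sign of a larger shift for this exchange. The expected change is a 1.1-fold lower number from compound 2 to compound 4 (0.04 log units; within the scatter), which would stay within the scatter. For compound 4 the estimated value is 28000 nM, with an expected range from 12000 nM to 60000 nM.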

Compound 4, half-maximal effective concentration: 500 nM
For compound 4 the middle estimate is 56-fold (1.75 log units) above the measured one, outside the stated range (below it).
By their numbers in this assay, from the lowest: compound 4; then compounds 1 and 2 (each within the scatter of the next).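

In this assay, going by these compounds alone, the exchange of 4-chlorophenyl for 4-methoxyphenyl gives a 62-fold lower number from compound 2 to compound 4 (1.79 log units; beyond the scatter) and, as the first single-place comparison, shows that this position is not indifferent: one substituent on an aromatic carbon, para to a large group, can move the read-out far beyond the scatter. The change counted between the two structures is small, since chloro, with 1 heavy atom, leaves and methoxy, with 2 heavy atoms and 1 hydrogen-bond acceptor, enters, with no ring and no net charge involved on either side. No measured property accompanies this step, and nothing available accounts for its size.

As far as these compounds go, with a single exchange at this position, it stays open whether the low number belongs to methoxy in particular or would also appear with a hydroxy, an ethoxy or a dimethylamino group, or with plain hydrogen, at the same place. From the compounds shown here alone, it also stays open whether methoxy in place of the trifluoromethoxy group of compound 1 would bring a step of similar size in that compound's frame.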